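This account rests on a few compounds, and the source may have more. Where it says the series, first, only, none or still open, it means among the compounds named here.

Compound 1 `Cc1cc(O)c(C2=NN(c3ccc(S(N)(=O)=O)cc3)C(c3ccccc3O)C2)cc1Cl` gives 7920 nM in a functional assay on MDA-MB-468 cells (Homo sapiens) for antiproliferative activity, with a stated time of 48 h; a higher number here means a weaker inhibitor of growth, a lower number a stronger inhibitor of growth.
Compound 2 `Cc1cc(O)c(C2=NN(c3ccc(S(N)(=O)=O)cc3)C(c3ccccc3Cl)C2)cc1Cl` gives 4740 nM in this assay.

Among the compounds with values here, of the two numbers measured so far, compound 1 stands highest with 7920 nM in this assay; the nearest is compound 2, whose value is 4740 nM. Within the data shown here, the single step between them, a 1.7-fold lower number from compound 1 to compound 2 (0.22 log units; within the scatter), lies within the scatter, so the two compounds cannot be set in order.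

Compound 3 `COc1ccc(C2CC(c3cc(Cl)c(C)cc3O)=NN2c2ccc(S(N)(=O)=O)cc2)c(OC)c1OC` differs from compound 1 by 2,3,4-trimethoxyphenyl in place of 2-hydroxyphenyl on a saturated ring carbon. Among the measured compounds shown here, no measured step exchanges the group at this saturated ring carbon; the only step available, from compound 1 to compound 2, replaces a hydroxy with a chloro on an aromatic carbon and is itself within the scatter. Nothing shown therefore points in either direction for the new aryl group, and the expectation rests on compound 1 alone. The writer expects compound 3 to show 6500 nM in this assay, within a range from 1500 nM to 28000 nM. The step this implies, a 1.2-fold lower number from compound 1 to compound 3 (0.09 log units; within the scatter), is estimated to stay within the scatter, with a wide uncertainty because the shown steps give no guide for a change of this kind.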

Compound 3, concentration for total growth inhibition: 9070 nM
Compound 3: the middle estimate sits 1.4-fold (0.14 log units) below what was measured; the measured number falls inside the stated range.
By their numbers in this assay, from the lowest: compounds 2, 1 and 3 (each within the scatter of the next).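

Compounds 1 and 2 differ only in one substituent on the aryl group at the saturated ring carbon, whereas compound 3 brings a much larger change to that group. In this assay the exchange of 2-hydroxyphenyl for 2,3,4-trimethoxyphenyl gives a 1.1-fold higher number from compound 1 to compound 3 (0.06 log units; within the scatter), and the exchange of 2-chlorophenyl for 2,3,4-trimethoxyphenyl gives a 1.9-fold higher number from compound 2 to compound 3 (0.28 log units; within the scatter), so going from 7 to 12 heavy atoms and from 1 hydrogen-bond donor to 0 on this group leaves both steps inside the scatter. Nothing available accounts for this result, and no independent measurement bears on it.

On these data alone, all three compounds carry a six-membered aromatic ring of carbon only at this position, so it remains open whether a group without one, such as a simple alkyl chain, or an aryl group bearing an amine or a carboxylic acid, would take the number beyond the scatter. The 4-sulfamoylphenyl and 5-chloro-2-hydroxy-4-methylphenyl groups are the same throughout, which leaves their contribution to the growth inhibition unknown.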